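A Ring Replaces a Branched Chain on the Double-Bonded Nitrogen

The source may hold more compounds than are shown below. What is called first, only, known or untested is meant among the compounds shown, and "the series" means these compounds.

Of the compounds shown here, three sharing one core have been tested in a functional assay on the whole organism (blood, strain Wistar-Okamoto) with Rattus norvegicus as the target, with a stated time of 5 days; a higher number here means that more compound is needed for the effect, a lower number that less compound is needed. Compound 1 `N#CN/C(=N\C1CCCCC1)Nc1cccnc1` gives 20 mg/kg. Compound 2 `CC(C)CC(C)/N=C(\NC#N)Nc1ccncc1` gives 35 mg/kg, and compound 3 `CCC(C)C(C)/N=C(\NC#N)Nc1ccncc1` gives 8 mg/kg. Of the three, compound 3 stands at the lowest number: compound 1 lies nearest with a higher value and compound 2 furthest, both gaps beyond the scatter. Going by the values given here, the only step between measured compounds that differ in a single place is a 4.4-fold lower number from compound 2 to compound 3 (0.64 log units; beyond the scatter). That step is a modest one, and the group that changes in it sits on the saturated chain carbon bound to a double-bonded nitrogen and a saturated chain carbon.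

Compound 4 `N#CN/C(=N\C1CCCCC1)Nc1ccncc1` has not yet been measured. It differs from compound 3 as follows: cyclohexyl in place of 1,2-dimethylbutyl on a double-bonded nitrogen. The leaving and entering groups carry the same count of heavy atoms; what changes is a ring in place of a branched chain. Among the compounds with values here, the step from compound 2 to compound 3 is the only measured step touching this part of the molecule, and it shows that reshaping the group here can move the number beyond the scatter. Within the data shown here, no measured pair sets a ring against a chain, so the direction is uncertain. Compound 4 is therefore expected to show a step of a 1.5-fold higher number from compound 3 to compound 4 (0.18 log units; within the scatter) in this assay. For compound 4 the value is estimated at 12 mg/kg, within a range from 5 mg/kg to 30 mg/kg.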

Compound 4, minimum effective dose: 20 mg/kg
For compound 4 the middle estimate is 1.7-fold (0.22 log units) below the measured one; low and high end bracket the measured number.
By their numbers in this assay, from the lowest: compound 3; then compounds 1, 4 and 2 (each within the scatter of the next).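

In this assay, cyclohexyl on the double-bonded nitrogen is now set directly against two branched chains, and the outcome depends on the chain: replacing 1,2-dimethylbutyl gives a 2.5-fold higher number from compound 3 to compound 4 (0.40 log units; beyond the scatter), whereas replacing 1,3-dimethylbutyl gives a 1.8-fold lower number from compound 2 to compound 4 (0.24 log units; within the scatter), so a ring in place of a chain has no single effect here even with the same count of heavy atoms in the case of compound 3 and compound 4. Going by these compounds alone, the result also gives the first reading at a second place in the molecule, the amine nitrogen, where pyridin-4-yl in place of pyridin-3-yl, with cyclohexyl held constant, gives no change at the digits printed from compound 1 to compound 4 (within the scatter). Nothing available explains these steps.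

The compounds shown leave open how cyclopentyl or an unbranched hexyl chain would compare with cyclohexyl and 1,2-dimethylbutyl on the double-bonded nitrogen. They also leave open whether pyridin-2-yl or a plain phenyl on the amine nitrogen would match the two pyridinyl groups, and whether those two groups would still match each other alongside 1,2-dimethylbutyl.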